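This account rests on a few compounds, and the source may have more. Where it says the series, first, only, none or still open, it means among the compounds named here.

Compound 1 `CC(=O)OC[C@H]1O[C@@H](n2cc(Cn3cc(C(C)=O)c4ccccc43)nn2)[C@H](OC(C)=O)[C@@H](OC(C)=O)[C@@H]1OC(C)=O` gives 75200 nM
Compound 2 `CC(=O)OC[C@H]1O[C@@H](n2cc(CN3C(=O)/C(=C/c4ccc(C)cc4)c4ccccc43)nn2)[C@H](OC(C)=O)[C@@H](OC(C)=O)[C@@H]1OC(C)=O` gives 9300 nM
Compound 3 `CC(=O)OC[C@H]1O[C@@H](n2cc(CN3C(=O)/C(=C\c4ccc(C)cc4)c4ccccc43)nn2)[C@H](OC(C)=O)[C@@H](OC(C)=O)[C@@H]1OC(C)=O` gives 9400 nM

In a functional assay on DU-145 cells (Homo sapiens) for cytotoxicity, read by sulforhodamine B assay, with a stated time of 48 h (on this read-out lower numbers stand for stronger inhibition and higher numbers for weaker inhibition), compound 2 stands at the lowest number of the three, with compound 3 beside it and compound 1 well apart. Among the compounds with values here, the only measured step, a 1.0-fold higher number from compound 2 to compound 3 (0.00 log units; within the scatter), rests on the fact that compounds 2 and 3 differ only in the configuration as drawn and leaves the number unchanged. Compound 4 `CCC/C=C1/C(=O)N(Cc2cn([C@@H]3O[C@H](COC(C)=O)[C@@H](OC(C)=O)[C@H](OC(C)=O)[C@H]3OC(C)=O)nn2)c2ccccc21` differs from compound 2 by propyl in place of 4-methylphenyl on a double-bonded chain carbon bound to a double-bonded ring carbon. Within the data shown here, no measured step alters a group at this position, so the measured evidence offers no guide to size or direction; the swap of an aromatic ring for a short chain is a larger change than the drawn configuration, and a move toward weaker inhibition is expected. Compound 4 is therefore expected to give 25000 nM, with a range from 8000 nM to 80000 nM. This estimate means a 2.7-fold higher number from compound 2 to compound 4 (0.43 log units; beyond the scatter).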

Compound 4, half-maximal inhibitory concentration: 19700 nM
The estimate for compound 4 lay 1.3-fold (0.10 log units) above the measured number; measured number inside the range.
By their numbers in this assay, from the lowest: compounds 2 and 3 (each within the scatter of the next); then compound 4; then compound 1.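

In this assay, the group on a double-bonded chain carbon bound to a double-bonded ring carbon affects the number, unlike the drawn configuration: propyl in place of 4-methylphenyl gives a 2.1-fold higher number from compound 2 to compound 4 (0.33 log units; beyond the scatter). The step is modest, so compound 4 keeps much of the inhibition without the aromatic ring. Nothing available here explains this step.

Going by these compounds, it remains open whether a longer chain, such as hexyl, would follow propyl or return toward 4-methylphenyl. An amine or a carboxylic acid on the phenyl ring is also untested among these compounds.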